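Heteroaryl in place of the basic amine on the core

The source may hold more compounds than are shown below. What is called first, only, known or untested is meant among the compounds shown, and "the series" means these compounds.

Measured so far in a functional assay for antagonist activity at transient receptor potential cation channel subfamily V member 1 (Homo sapiens), read by FLIPR; on this read-out lower numbers stand for stronger inhibition and higher numbers for weaker inhibition:
- compound 1, `CC(C)(C)c1ccc(NC(=O)c2ccc(-c3ncccc3N(S(C)(=O)=O)S(C)(=O)=O)cc2)cc1`: 0.8 nM
- compound 2, `CC(C)(C)c1ccc(NC(=O)c2ccc(-c3ncccc3C(=O)O)cc2)cc1`: the value of compound 2 is a limit of the assay, > 4000 nM
- compound 3, `CN(C)Cc1cccnc1-c1ccc(C(=O)Nc2ccc(C(C)(C)C)cc2)cc1`: 746 nM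

Compound 3 gives the highest of the two numbers shown; the nearest is compound 1, with a 930-fold higher number from compound 1 to compound 3 (2.97 log units; beyond the scatter). The value of compound 2 sits at a limit (the limit of > 4000 nM in this assay, at which 1 of the 3 values shown sits), so it stands outside any ordering by number.

Compound 4, `CC(C)(C)c1ccc(NC(=O)c2ccc(-c3ncccc3-c3ncc[nH]3)cc2)cc1`, differs from compound 3 by 1H-imidazol-2-yl in place of (dimethylamino)methyl on an aromatic carbon.

Among the measured compounds shown here, the steps that bear on this position are an at least 5000-fold higher number from compound 1 to compound 2 (3.69 log units; beyond the scatter) and an at least 5.3-fold lower number from compound 2 to compound 3 (0.72 log units; beyond the scatter), together with the step from compound 1 above. For the measured compounds named here, both exchanges at this carbon were large or at least modest, so the group here matters strongly, but no measured step covers an aromatic heterocycle at this place. Compound 4 is therefore expected at 300 nM, within 30 nM to 3000 nM, which would mean an estimated 2.5-fold lower number from compound 3 to compound 4 (0.40 log units; beyond the scatter).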

Compound 4, half-maximal inhibitory concentration: 3670 nM
For compound 4 the middle estimate is 12-fold (1.09 log units) below the measured one; the whole stated range lies below it.
By their numbers in this assay, from the lowest: compound 1; then compound 3; then compound 4. At a limit, above all of these: compound 2.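

In this assay an aromatic heterocycle at this carbon does not recover the activity of compound 1: 1H-imidazol-2-yl falls behind (dimethylamino)methyl (a 4.9-fold higher number from compound 3 to compound 4 (0.69 log units; beyond the scatter)) and stays far from bis(methylsulfonyl)amino (a 4600-fold higher number from compound 1 to compound 4 (3.66 log units; beyond the scatter)). Among the four groups shown, only bis(methylsulfonyl)amino gives a low number, so a five-membered aromatic ring joins carboxy and (dimethylamino)methyl on the weak side of the series. Compound 2 is a limit of the assay: the limit of > 4000 nM in this assay, at which 1 of the 4 values shown sits. That limit leaves only a floor for the remaining step, an at least 1.0-fold lower number from compound 2 to compound 4 (0.03 log units; that floor lies within the scatter).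

Open, on these data alone, is whether a single methylsulfonylamino group would keep the low number of compound 1. Also open, as far as these compounds go, is whether 1-methylimidazol-2-yl would differ from 1H-imidazol-2-yl at this carbon.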